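Dichlorophenyl swap in a series sitting at the limit

This account rests on a few compounds, and the source may have more. Where it says the series, first, only, none or still open, it means among the compounds named here.

Measured compounds:
compound 1 `N#CC1=C(N)Oc2c(N)cc3nc4ccccc4nc3c2C12C(=O)N(Cc1cnnn1-c1ccc(F)cc1)c1ccccc12` — > 50000 nM
compound 2 `CCOc1ccc(-n2nncc2CN2C(=O)C3(C(C#N)=C(N)Oc4c(N)cc5nc6ccccc6nc5c43)c3ccccc32)cc1` — > 50000 nM
compound 3 `Cc1ccc(-n2nncc2CN2C(=O)C3(C(C#N)=C(N)Oc4c(N)cc5nc6ccccc6nc5c43)c3ccccc32)cc1C` — > 50000 nM

Three compounds share one core and differ only in the aryl group on an aromatic nitrogen of the five-membered ring with three nitrogens. In a functional assay on HepG2 cells (Homo sapiens) for antiproliferative activity, read by MTT assay, with a stated time of 48 h (on this read-out higher numbers stand for weaker inhibition and lower numbers for stronger inhibition), compound 1 reaches only a limit, > 50000 nM. Compound 2 likewise gives only a limit in this assay, > 50000 nM. Compound 3 also stands at a limit in this assay, > 50000 nM. Because all three sit at the limit of > 50000 nM in this assay, at which 3 of the 3 values shown sit, none of the steps among them can be read: the step that the two limits leave unreadable from compound 1 to compound 2, the step that the two limits leave unreadable from compound 1 to compound 3 and the step that the two limits leave unreadable from compound 2 to compound 3 are all unreadable in size and direction.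

Compound 4 `N#CC1=C(N)Oc2c(N)cc3nc4ccccc4nc3c2C12C(=O)N(Cc1cnnn1-c1cc(Cl)ccc1Cl)c1ccccc12` is the next member. It differs from compound 3 by 2,5-dichlorophenyl in place of 3,4-dimethylphenyl on an aromatic nitrogen. Going by the values given here, the steps that bear on this change are those from compound 1 to compound 3 and from compound 2 to compound 3, both aryl exchanges at the same nitrogen, and both left unreadable by the limits. Among the compounds with values here, no measured step therefore gives a size or direction for this assay. The expectation for compound 4 is that it too stays at the limit, so the estimated step that the limit leaves unreadable from compound 3 to compound 4 is none beyond the scatter. Compound 4 is expected at 60000 nM, within 15000 nM to 250000 nM.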

Compound 4, half-maximal inhibitory concentration: 33100 nM
Beside the measured number, compound 4's estimate is 1.8-fold (0.26 log units) above it, within the range that was stated.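

In this assay compound 4 is the only one of the four shown that gives a number and not a limit, so a change of the aryl group on this aromatic nitrogen can now be read, at least in direction. The exchange for 2,5-dichlorophenyl gives an at least 1.5-fold lower number from compound 3 to compound 4 (0.17 log units; that floor lies within the scatter), an at least 1.5-fold lower number from compound 2 to compound 4 (0.17 log units; that floor lies within the scatter) and an at least 1.5-fold lower number from compound 1 to compound 4 (0.17 log units; that floor lies within the scatter). These are floors and not sizes, and the steps among the other three compounds still cannot be read, because each of those compounds stands at a limit: the limit of > 50000 nM in this assay, at which 3 of the 4 values shown sit.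

The compounds shown leave open whether the chlorine atoms of 2,5-dichlorophenyl are both needed for the value of compound 4, or whether a phenyl group bearing one chlorine would serve as well. They also leave open whether an amine or a carboxylic acid on this aryl group, or a pyridyl group in its place, would move the number further from the limit.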